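A few compounds are considered here, and "the series" means these few. Any claim that something is new, unique, unknown or untested is made for them only; others in the source may bear on it.

Measured compounds:
- compound 2, `Cc1c(C(=O)CSCCNC(=O)c2ccccc2)[n+]([O-])c2ccccc2[n+]1[O-]`: > 100 ug/mL
- compound 1, `Cc1c(C(=O)CSCCN)[n+]([O-])c2ccccc2[n+]1[O-]`: "not determined" (no result reported)

Compound 2 stands at a limit in an ADME assay on Vero cells (Chlorocebus sabaeus) for cytotoxicity, read by MTT assay, with a stated time of 72 h; a higher number here means that more compound is tolerated, a lower number that less compound is tolerated: its value of > 100 ug/mL is the upper limit of the assay and not a number, as noted in the limit of > 100 ug/mL in this assay, at which 1 of the 2 values shown sits. Within the data shown here, compound 1 has no result in this assay, so the set holds no step between two measured compounds and no measured size of change to lean on.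

Compound 3, `Cc1c(C(=O)CSCCNC(=O)c2ccc(F)cc2)[n+]([O-])c2ccccc2[n+]1[O-]`, differs from compound 2 by fluoro in place of hydrogen on an aromatic carbon. The shared core and the rest of the chain are unchanged. With only a limit for compound 2, the step from compound 2 to compound 3 cannot be read against the scatter; it is expected to be none beyond the scatter, a step that the limit leaves unreadable from compound 2 to compound 3, and the assay is most likely to report a limit again. Compound 3 is estimated at 150 ug/mL, with a range from 70 ug/mL to 300 ug/mL.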

Compound 3, half-maximal cytotoxic concentration: > 100 ug/mL
Compound 3: a limit, no number; the forecaster's own chance of this, stated with the estimate: 80%; the middle value is on the limit's open side.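

Compound 2 and compound 3 both return a limit and no number in this assay, so no step can be read between them. The compounds shown leave open how far either lies past that limit, and whether fluoro in place of hydrogen on an aromatic carbon changes anything.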